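The source may hold more compounds than are shown below. What is called first, only, known or untested is meant among the compounds shown, and "the series" means these compounds.

Compound 2 `CC(C)CCOC(=O)C(O)Cn1cnc2c(N)ncnc21` shares its core with compound 1 `COC(=O)C(O)Cn1cnc2c(N)ncnc21` and differs from it only in the ester part. In a functional assay on Vero cells (Chlorocebus sabaeus) for cytotoxicity (on this read-out lower numbers stand for higher toxicity in this test and higher numbers for lower toxicity in this test), compound 2 gives 400 ug/mL, the single numerical value among the measurements shown. Compound 1 gives a limit of the assay, > 400 ug/mL, in this assay. The step of a number no higher from compound 1 to compound 2 (the limit leaves the size open) cannot be sized, since one of its ends sits at the limit of > 400 ug/mL in this assay, at which 1 of the 2 values shown sits. Compound 3 `CC(C)(C)OC(=O)C(O)Cn1cnc2c(N)ncnc21` differs from compound 2 by tert-butyl in place of isopentyl on an oxygen next to a carbonyl group. For the measured compounds named here, the only measured step concerns a substituent on the same oxygen next to a carbonyl group and shows no readable change, so swapping one alkyl group for another there gives no reason to expect a shift beyond the scatter. The step of no change at the digits printed from compound 2 to compound 3 (within the scatter) that this estimate means is expected to stay within the scatter. Compound 3 is therefore expected to give about 400 ug/mL, with a range from 200 ug/mL to 800 ug/mL, in this assay.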

Compound 3, minimum cytotoxic concentration: > 400 ug/mL
Compound 3: only a limit was reported; the forecaster's own chance of this, stated with the estimate: 50%; the middle value lies on the limit itself.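

The change from isopentyl to tert-butyl on an oxygen next to a carbonyl group gives a number no lower from compound 2 to compound 3 (the limit leaves the size open) in this assay, so this swap at the ester oxygen leaves no number to compare. The step from compound 1 to compound 3 cannot be read either, as both of its ends are limits. Compound 3 thus stands with compound 1 at a limit of the assay, and of the three ester groups only isopentyl, in compound 2, gives a number: the limit of > 400 ug/mL in this assay, at which 2 of the 3 values shown sit.

On these data alone, what compound 1 and compound 3 would read beyond that limit stays open, and with it the size of any gap among the three esters. Also open, as far as these compounds go, is how this assay would read with a longer chain or a benzyl group on this oxygen, or with a free carboxylic acid in place of the ester.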